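The source may report more compounds than this note shows. Statements on the series, on what has been measured and on what is new or still open speak of the compounds shown alone.

Measured in an ADME assay on MT4 cells (Homo sapiens) for cytotoxicity, with a stated time of 5 days; on this read-out higher numbers stand for lower toxicity in this test and lower numbers for higher toxicity in this test:

- Compound 1 `CC(C)(C)C#Cc1cc(N(C(=O)[C@H]2CC[C@H](C)CC2)[C@H]2CC[C@H](Oc3ccc4nccn4n3)CC2)c(C(=O)O)s1`: > 20000 nM
- Compound 2 `CC(C)(C)C#Cc1cc(N(C(=O)[C@H]2CC[C@H](C)CC2)[C@H]2CC[C@H](Oc3ccc(=O)[nH]n3)CC2)c(C(=O)O)s1`: > 20000 nM

Compound 2 gives > 20000 nM, and this is a limit of the assay, not a number. Compound 1 gives > 20000 nM, which is likewise a limit. The two compounds therefore share one position: the limit of > 20000 nM in this assay, at which 2 of the 2 values shown sit. Neither has a numerical reading from which to rank it.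

Compound 3 `CC(C)(C)C#Cc1cc(N(C(=O)[C@H]2CC[C@H](C)CC2)[C@H]2CC[C@H](Oc3ccncn3)CC2)c(C(=O)O)s1` keeps the shared core and changes one group: a group of 6 heavy atoms (4 carbon, 2 nitrogen; one six-membered aromatic ring with 2 hetero atoms) in place of a group of 7 heavy atoms (4 carbon, 2 nitrogen, 1 oxygen; one six-membered aromatic ring with 2 hetero atoms), on an oxygen on a saturated carbon. The incoming pyrimidin-4-yl has 0 hydrogen-bond donors, whereas the group that leaves has 1.

For the measured compounds named here, only one measured step bears on this change, as it alters the group on the same oxygen: a step that the two limits leave unreadable from compound 1 to compound 2. It gives no size to carry over, but neither of its two compounds has a reading that falls short of the limit. On that limited basis, no step beyond the usual scatter is expected in this assay, and no direction can be assigned. A further report as a limit is the most likely outcome. The expected change is a number no higher from compound 2 to compound 3 (the limit leaves the size open). For compound 3 the estimated value is 20000 nM, with an expected range from 9000 nM to 30000 nM.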

Compound 3, half-maximal cytotoxic concentration: > 20000 nM
Compound 3 was reported as a limit; the forecaster's own chance of this, stated with the estimate: 85%; the middle value lies on the limit itself.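

Compound 3 gives > 20000 nM in this assay, which is a limit of the assay, so no step among compound 1, compound 2 and compound 3 can be read: the limit of > 20000 nM in this assay, at which 3 of the 3 values shown sit.

The compounds shown leave open whether, and by how much, the three groups on the oxygen differ in this assay.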